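The source may hold more compounds than are shown below. What is called first, only, known or untested is meant among the compounds shown, and "the series" means these compounds.

Measured so far in a functional assay on A549 cells (Homo sapiens) for antiproliferative activity, read by sulforhodamine B assay, with a stated time of 48 h; on this read-out lower numbers stand for stronger inhibition and higher numbers for weaker inhibition:
- compound 1 `COc1ccc(C[C@@H](O)/C=C/C=C/C(=O)N2CCCCC2)cc1OC` gives 16400 nM
- compound 2 `COc1ccc(C[C@@H](O)/C=C/C=C/C(=O)N2CCN(C)CC2)cc1OC` gives 22200 nM

Compound 2, at 22200 nM, stands within the scatter of compound 1, so the two values are not separated in this assay. Compound 3 `COc1ccc(C[C@@H](O)/C=C/C=C/C(=O)N2CCCC2)cc1OC` has not yet been measured. It differs from compound 2 as follows: pyrrolidin-1-yl in place of 4-methylpiperazin-1-yl on a carbonyl carbon. Among the compounds with values here, one measured step bears on this place: a 1.4-fold higher number from compound 1 to compound 2 (0.13 log units; within the scatter), which lies within the scatter. Within the data shown here, no compound with pyrrolidin-1-yl has a measured value yet. On this single step, no change beyond the scatter is expected in this assay, in either direction. The expected step is small: a 1.2-fold lower number from compound 2 to compound 3 (0.09 log units; within the scatter). For compound 3 the estimated value is 18000 nM, with an expected range from 9000 nM to 36000 nM.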

Compound 3, half-maximal inhibitory concentration: 24400 nM
For compound 3 the middle estimate is 1.4-fold (0.13 log units) below the measured one, and the stated range covers the measured number.
By their numbers in this assay, from the lowest: compounds 1, 2 and 3 (each within the scatter of the next).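

In this assay, the place on the carbonyl carbon now holds a five-membered non-aromatic ring with 1 hetero atom as well as the two six-membered rings, and pyrrolidin-1-yl stays within the scatter of both (a 1.1-fold higher number from compound 2 to compound 3 (0.04 log units; within the scatter); a 1.5-fold higher number from compound 1 to compound 3 (0.17 log units; within the scatter)). Ring size and the 4-methylpiperazin-1-yl ring's second nitrogen therefore give no separation among these three compounds, and no order among them can be stated. No measured property of these compounds is available to account for the values.

Still open, on these data alone, is whether a ring-free amide, such as diethylamino or the unsubstituted amide, would move the value beyond the scatter at this place. Also open, as far as these compounds go, is whether a charged side chain, such as a longer aminoalkyl group on the amide nitrogen, would do so.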